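This account rests on a few compounds, and the source may have more. Where it says the series, first, only, none or still open, it means among the compounds named here.

Compound 1 `COc1cc(OCc2cccc(-c3ccc(C#N)cn3)c2)c2cc(-c3cn4nc(OC)sc4n3)oc2c1` gives 464 ng.h/mL in an ADME assay on the whole organism (Rattus norvegicus), at a dose of 2 mg/kg by the oral route; on this read-out lower numbers stand for lower exposure and higher numbers for higher exposure at the dose given. This is the lower of two numbers, and compound 2 `COc1cc(OCc2csc(-c3ccc(C(C)(C)O)cc3)n2)c2cc(-c3cn4nc(OC)sc4n3)oc2c1` stands close by with 505 ng.h/mL; the two lie within the usual scatter, so neither can be set apart from the other. Compound 3 `COc1cc(OCc2cccc(-c3ccc(C#N)cc3)c2)c2cc(-c3cn4nc(OC)sc4n3)oc2c1` differs from compound 1 in one place: 4-cyanophenyl in place of 5-cyanopyridin-2-yl on an aromatic carbon. Among the compounds with values here, no comparable pair of measured compounds shows how such a change plays out, so the step is expected to stay within the scatter, with no clear direction. On that basis compound 3 is estimated at 420 ng.h/mL, with a range from 150 ng.h/mL to 1200 ng.h/mL, which is a step of a 1.1-fold lower number from compound 1 to compound 3 (0.04 log units; within the scatter) that is expected rather than known.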

Compound 3, area under the concentration-time curve: 610 ng.h/mL
For compound 3 the middle estimate is 1.5-fold (0.16 log units) below the measured one, within the range that was stated.
By their numbers in this assay, from the lowest: compounds 1, 2 and 3 (each within the scatter of the next).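

In this assay, putting 4-cyanophenyl in place of 5-cyanopyridin-2-yl gives a 1.3-fold higher number from compound 1 to compound 3 (0.12 log units; within the scatter). Within the data shown here, at this position, then, the nitrogen of the pyridine ring can be exchanged for carbon with no step that stands clear of the scatter. Nothing measured on these compounds offers an explanation for this result. Still open, as far as these compounds go, is whether a different group in place of the nitrile on this ring, such as an amine or a carboxylic acid, would give a step beyond the scatter. A single pair also cannot show whether this exchange would play out the same way on another core.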